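Methoxy on the urea phenyl of a potent urea

A few compounds are considered here, and "the series" means these few. Any claim that something is new, unique, unknown or untested is made for them only; others in the source may bear on it.

Compound 3 `CN(C(=O)Nc1ccccc1)c1ccc2[nH]c(-c3n[nH]c4ccccc34)cc2n1` is the most potent of the three measured compounds in a functional assay on HCT-116 cells (Homo sapiens) for antiproliferative activity, read by MTT assay, with a stated time of 72 h (on this read-out lower numbers stand for stronger inhibition and higher numbers for weaker inhibition), at 1.3 nM. Compound 1 `CN(C(=O)CCc1ccccc1)c1ccc2[nH]c(-c3n[nH]c4ccccc34)cc2n1` gives 11200 nM and compound 2 `CN(C(=O)c1ccc(F)cc1)c1ccc2[nH]c(-c3n[nH]c4ccccc34)cc2n1` gives 9270 nM; the steps of an 8600-fold lower number from compound 1 to compound 3 (3.94 log units; beyond the scatter) and a 7100-fold lower number from compound 2 to compound 3 (3.85 log units; beyond the scatter) are both large, whereas a 1.2-fold lower number from compound 1 to compound 2 (0.08 log units; within the scatter) is not. Compound 4 `COc1ccc(NC(=O)N(C)c2ccc3[nH]c(-c4n[nH]c5ccccc45)cc3n2)cc1` differs from compound 3 by methoxy in place of hydrogen on an aromatic carbon. Among the compounds with values here, no measured step isolates a substituent on the urea phenyl; the single fluorinated compound, compound 2, belongs to an amide pair where the chain changes as well. The step of a 1.2-fold higher number from compound 3 to compound 4 (0.06 log units; within the scatter) is therefore expected to stay within the scatter, and compound 4 is estimated at 1.5 nM, within 0.4 nM to 6 nM.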

Compound 4, half-maximal inhibitory concentration: 63 nM
Compound 4: the middle estimate sits 42-fold (1.62 log units) below what was measured; measured number above the stated range.
By their numbers in this assay, from the lowest: compound 3; then compound 4; then compounds 2 and 1 (each within the scatter of the next).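

In this assay, the urea phenyl proves sensitive to substitution: methoxy on this aromatic carbon, para to a large group, weakens the compound (a 48-fold higher number from compound 3 to compound 4 (1.69 log units; beyond the scatter)). The urea with methoxy still stays well ahead of both amides (a 150-fold lower number from compound 2 to compound 4 (2.17 log units; beyond the scatter); a 180-fold lower number from compound 1 to compound 4 (2.25 log units; beyond the scatter)), so the methoxy step gives back only part of what the anilino group gained. No experimental evidence on these compounds accounts for the loss. Whether the loss is specific to methoxy stays open, since the compounds shown include no fluoro, methyl or hydroxy at this carbon. They also leave open how methoxy would behave on another carbon of this ring.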